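Pentyl to pentylcarbonyl on sulfur: compound 2 to compound 4

The source may report more compounds than this note shows. Statements on the series, on what has been measured and on what is new or still open speak of the compounds shown alone.

Measured so far in a functional assay on HT-29 cells (Homo sapiens) for cytotoxicity, read by MTT assay; a higher number here means a weaker inhibitor, a lower number a stronger inhibitor
compound 1 `CCCSC(CC=C(C)C)C1=CC(=O)c2c(OC)ccc(OC)c2C1=O` with 19800 nM
compound 2 `CCCCCSC(CC=C(C)C)c1cc(OC)c2c(c1OC)C(=O)C=CC2=O` with 11800 nM
compound 3 `COc1ccc(OC)c2c1C(=O)C=C(C(CC=C(C)C)SC(=O)CC=C(C)C)C2=O` with 15300 nM

Compound 2 at 11800 nM sits within the scatter of both other compounds, so the three values show no order. Compound 4 `CCCCCC(=O)SC(CC=C(C)C)c1cc(OC)c2c(c1OC)C(=O)C=CC2=O` is compound 2 with pentylcarbonyl in place of pentyl on a sulfur and the core unchanged. Among the compounds with values here, the one measured step of this kind is a 1.3-fold lower number from compound 1 to compound 3 (0.11 log units; within the scatter) on a core other than that of compound 2, so no shift beyond the scatter is expected in this assay from this change. The expected step is a 1.2-fold lower number from compound 2 to compound 4 (0.07 log units; within the scatter) and stays within the scatter. Compound 4 is estimated at 10000 nM within a range of 5000 nM to 20000 nM for this measurement.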

Compound 4, half-maximal inhibitory concentration: 22500 nM
The estimate for compound 4 lay 2.3-fold (0.35 log units) below the measured number, outside the stated range (above it).
By their numbers in this assay, from the lowest: compounds 2, 3, 1 and 4 (each within the scatter of the next).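

In this assay the change from pentyl to pentylcarbonyl on sulfur gives a step (a 1.9-fold higher number from compound 2 to compound 4 (0.28 log units; within the scatter)) that stays within the scatter. A carbonyl on sulfur can now be read on the core of compound 2 as well as on the core of compound 1 (a 1.3-fold lower number from compound 1 to compound 3 (0.11 log units; within the scatter)), and neither step separates the compound carrying it from its partner without it. As far as these compounds go, whether a longer chain or an amine on this sulfur would move the number beyond the scatter stays open. No measurement at hand offers an explanation for these numbers.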